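This account rests on a few compounds, and the source may have more. Where it says the series, first, only, none or still open, it means among the compounds named here.

Measured compounds:
Compound 1 `COc1ccc(/C(=C\c2c[nH]c3ccc(OCc4ccccc4)cc23)C(=O)O)cc1` gives 38100 nM in a functional assay on DU-145 cells (Homo sapiens) for cytotoxicity, read by MTT assay, with a stated time of 72 h; a lower number here means a stronger inhibitor, a higher number a weaker inhibitor.
Compound 2 `CC(=O)n1cc(/C=C(/C(=O)O)c2ccc(OCc3ccccc3)cc2)c2cc(OCc3ccccc3)ccc21` gives 1410 nM in this assay.
Compound 3 `COc1ccccc1/C(=C\c1cn(C(C)=O)c2ccc(OCc3ccccc3)cc12)C(=O)O` gives 1010 nM in this assay.

Compound 3 has the lowest number of the three in this assay. Its nearest neighbour is compound 2, and that gap lies within the scatter, so no order can be read between compound 2 and compound 3. For the measured compounds named here, compound 1 stands far from compound 3, well beyond the scatter, but compound 1 differs from compound 3 in more than one place, so no single step is defined there.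

Compound 4 `COc1cc(OC)cc(/C(=C\c2cn(C(C)=O)c3ccc(OCc4ccccc4)cc23)C(=O)O)c1` is not yet measured. It differs from compound 3 in one place: 3,5-dimethoxyphenyl in place of 2-methoxyphenyl on a double-bonded chain carbon bound to a carbonyl carbon and a double-bonded chain carbon. Going by the values given here, no pair of measured compounds differs in this way at this position, so the size of this step cannot be taken from the data. With both the leaving and the entering group being a methoxy-bearing six-membered aromatic ring of carbon only, a small step is expected, in this assay likely a modest rise in the number from compound 3 to compound 4, of about a 1.6-fold higher number from compound 3 to compound 4 (0.20 log units; within the scatter), possibly none beyond the scatter. For compound 4 in this assay the estimate is 1600 nM, with a range from 450 nM to 6000 nM.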

Compound 4, half-maximal inhibitory concentration: 880 nM
Estimate against measurement, compound 4: 1.8-fold (0.26 log units) above; measured number inside the range.
By their numbers in this assay, from the lowest: compounds 4, 3 and 2 (each within the scatter of the next); then compound 1.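

In this assay, replacing 2-methoxyphenyl with 3,5-dimethoxyphenyl on a double-bonded chain carbon bound to a carbonyl carbon and a double-bonded chain carbon gives a 1.1-fold lower number from compound 3 to compound 4 (0.06 log units; within the scatter), a step within the scatter. For the compounds shown here, this is the first single-place step, and it shows that, for this pair, the place accepts a different methoxy-bearing phenyl group, with one more methoxy group, without a readable shift in the number. No measurement is available that would explain this result.

Both groups compared here are methoxy-bearing phenyl groups, so the step says nothing about how an unsubstituted phenyl, a phenyl carrying an amine or a carboxylic acid, or a longer alkyl chain in place of the ring would read at this place. Compound 1 differs from compound 3 and compound 4 in more than one place, so its distance from them cannot be read as a single step, and the separate contributions of those differences stay unresolved.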